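The source may report more compounds than this note shows. Statements on the series, on what has been measured and on what is new or still open speak of the compounds shown alone.

Compound 1, `CCCSc1nc(Cl)c2c(n1)N(Cc1cccs1)C(C(=O)N1CCN(C)CC1)N2`: 39400 nM
Compound 2, `CCCSc1nc(Cl)c2c(n1)N(Cc1ccccc1)C(C(=O)OCC)N2`: a limit, > 64000 nM
Compound 3, `CCCSc1nc(Cl)c2c(n1)N(Cc1ccccc1)C(C(=O)NCCNC(=O)OC(C)(C)C)N2`: a limit, > 64000 nM

In a functional assay on TE-1 cells (Homo sapiens) for antiproliferative activity, read by MTT assay, with a stated time of 72 h (on this read-out lower numbers stand for stronger inhibition and higher numbers for weaker inhibition), compound 3 stands at a limit, (the limit of > 64000 nM in this assay, at which 2 of the 3 values shown sit). The step that the two limits leave unreadable from compound 2 to compound 3 is thus unreadable in size. Compound 4, `CCCSc1nc(Cl)c2c(n1)N(Cc1ccccc1)C(C(=O)N1CCN(C)CC1)N2`, has not been measured in this assay; it differs from compound 3 by 4-methylpiperazin-1-yl in place of (2-((tert-butoxycarbonyl)amino)ethyl)amino on a carbonyl carbon. Among the measured compounds shown here, none of the measured steps gives a readable size for a change of this kind, so no direction can be drawn from them. Compound 1, which also bears a 4-methylpiperazin-1-yl group on a carbonyl carbon, gives 39400 nM in this assay, a number rather than a limit. Compound 4 is therefore expected near 40000 nM, in the range 15000 nM to 90000 nM. The expected step of an at least 1.6-fold lower number from compound 3 to compound 4 (0.20 log units; that floor lies within the scatter) remains unreadable against a limit.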

Compound 4, half-maximal inhibitory concentration: 42500 nM
Compound 4: the middle estimate sits 1.1-fold (0.03 log units) below what was measured, and the stated range covers the measured number.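

In this assay, 4-methylpiperazin-1-yl on the carbonyl carbon gives a number with phenyl as well as with thiophen-2-yl, and exchanging those two groups is a 1.1-fold higher number from compound 1 to compound 4 (0.03 log units; within the scatter). Against the two other carbonyl substituents, the change reads an at least 1.5-fold lower number from compound 3 to compound 4 (0.17 log units; that floor lies within the scatter) and an at least 1.5-fold lower number from compound 2 to compound 4 (0.17 log units; that floor lies within the scatter). Both of these floors rest on a limit: the limit of > 64000 nM in this assay, at which 2 of the 4 values shown sit.

Going by these compounds, whether a primary amine, a carboxylic acid or a morpholine on this carbonyl carbon would lower the number remains open. So does whether any change here gives a step beyond the scatter.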